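Aryl Sulfonamide Variation on a Hydroxamic Acid Scaffold

The compounds below may be only part of what the source reports. "The series", "measured", "known", "first", "only" and "open" are said of these compounds alone.

Measured compounds and their values:
Compound 1, `Cc1ccc(S(=O)(=O)N2CCN(c3ncc(/C=C/C(=O)NO)s3)CC2)cc1`, gives 2000 nM in a functional assay on MCF7 cells (Homo sapiens) for antiproliferative activity; on this read-out higher numbers stand for weaker inhibition of growth and lower numbers for stronger inhibition of growth.
Compound 2, `O=C(/C=C/c1cnc(N2CCN(S(=O)(=O)c3ccc(C(F)(F)F)cc3)CC2)s1)NO`, gives 3000 nM in this assay.
Compound 3, `COc1ccc(S(=O)(=O)N2CCN(c3ncc(/C=C/C(=O)NO)s3)CC2)cc1OC`, gives 4000 nM in this assay.

Compound 3 carries the highest number of the three. The steps of a 2.0-fold higher number from compound 1 to compound 3 (0.30 log units; within the scatter) and a 1.3-fold higher number from compound 2 to compound 3 (0.12 log units; within the scatter) are both within the scatter, so the three compounds cannot be ranked against one another on these numbers.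

Compound 4, `O=C(/C=C/c1cnc(N2CCN(S(=O)(=O)c3ccccc3)CC2)s1)NO`, differs from compound 3 by phenyl in place of 3,4-dimethoxyphenyl on a sulfonyl sulfur. Every measured step in this set changes the same part of the molecule, the group on the sulfonyl sulfur: a 1.5-fold higher number from compound 1 to compound 2 (0.18 log units; within the scatter), a 2.0-fold higher number from compound 1 to compound 3 (0.30 log units; within the scatter) and a 1.3-fold higher number from compound 2 to compound 3 (0.12 log units; within the scatter). None of these steps reached beyond the scatter, and the remaining part of the structure is shared by all three measured compounds. On that basis no step beyond the scatter is expected for the change to compound 4, in either direction, which is the meaning of the expected step of a 1.3-fold lower number from compound 3 to compound 4 (0.12 log units; within the scatter). Compound 4 is therefore estimated to give 3000 nM in this assay, with a range from 1200 nM to 7500 nM.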

Compound 4, concentration for 50% growth inhibition: 3000 nM
Beside the measured number, compound 4's estimate shows no gap at the digits printed; low and high end bracket the measured number.
By their numbers in this assay, from the lowest: compounds 1, 2, 4 and 3 (each within the scatter of the next).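

In this assay, phenyl on the sulfonyl sulfur stays within the scatter of all three substituted aryl groups, with a 1.3-fold lower number from compound 3 to compound 4 (0.12 log units; within the scatter), no change at the digits printed from compound 2 to compound 4 (within the scatter) and a 1.5-fold higher number from compound 1 to compound 4 (0.18 log units; within the scatter) as the steps. The earlier compounds all carried a substituted ring at this position, so they could compare substituents only with one another; compound 4 adds the unsubstituted reference and shows that, among these four compounds, methyl, trifluoromethyl and the 3,4-dimethoxy pattern each leave the number within the scatter of plain phenyl. No measurement offers an explanation for this result.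

Still open, on these data alone, is whether an aromatic ring bearing an amine or a carboxylic acid, or a benzyl group or a simple alkyl chain on the sulfonyl sulfur, would give a step beyond the scatter. The compounds shown also leave open how much changes to the shared core would move the number.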